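The compounds below may be only part of what the source reports. "The series", "measured", "known", "first", "only" and "open" are said of these compounds alone.

Three triazenes have been examined in an ADME assay on MDBK cells (Bos taurus) for cytotoxicity, read by MTT assay, with a stated time of 96 h; on this read-out higher numbers stand for lower toxicity in this test and lower numbers for higher toxicity in this test. Compound 1 `c1ccc(/N=N/N2CCCCC2)cc1` carries no ring substituent; in this assay compound 1 gives > 100000 nM, which is a limit of the assay rather than a number. Compound 2 `Clc1ccc(/N=N/N2CCCC2)cc1` differs from compound 1 in a way that is not broken down here. In this assay compound 2 gives > 100000 nM, again a limit. Compound 3 `Clc1ccc(/N=N/N2CCCC2)cc1Cl` adds to compound 2 a chloro in place of hydrogen on an aromatic carbon; in this assay compound 3 gives 70000 nM. Going by these compounds, the resulting step, an at least 1.4-fold lower number from compound 2 to compound 3 (0.15 log units; that floor lies within the scatter), is floored by the limit of > 100000 nM in this assay, at which 2 of the 3 values shown sit, so its true size remains open. Compound 4 `Clc1ccc(/N=N/N2CCCCC2)cc1` has not yet been measured; it stands to compound 1 as compound 3 stands to compound 2, through the same kind of change (chloro in place of hydrogen on an aromatic carbon), though here the chloro enters para to a group of 8 heavy atoms rather than ortho to a chloro group and meta to a group of 7 heavy atoms. Because the same kind of change produced only an at least 1.4-fold lower number from compound 2 to compound 3 (0.15 log units; that floor lies within the scatter), compound 4 is expected to give about 110000 nM, between 50000 nM and 300000 nM, quite possibly reported only as a limit. The expected step from compound 1 to compound 4 is therefore a step that the limit leaves unreadable from compound 1 to compound 4.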

Compound 4, half-maximal cytotoxic concentration: > 100000 nM
Compound 4 ended at the assay's limit; the forecaster's own chance of this, stated with the estimate: 60%; the middle value lies beyond the limit too.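

In this assay compound 4 gives > 100000 nM, which is a limit and not a number. No step can be read from compound 1 to compound 4, because both values stand at a limit: the limit of > 100000 nM in this assay, at which 3 of the 4 values shown sit.

The compounds shown leave open whether chloro in place of hydrogen changes the read-out on the core of compound 1 at all.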